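Thiazole for thiophene on the amine-bearing carbon

A few compounds are considered here, and "the series" means these few. Any claim that something is new, unique, unknown or untested is made for them only; others in the source may bear on it.

Compound 1 `Cc1ccc(CN[C@@H]2C[C@H]3C[C@@H]([C@H]2C)C3(C)C)s1` is one of three measured compounds sharing a bicyclic amine core. In an ADME assay on MDCK cells (Canis lupus familiaris) for cytotoxicity, read by microscopy, with a stated time of 48 h (on this read-out higher numbers stand for lower toxicity in this test and lower numbers for higher toxicity in this test), compound 1 gives 780 nM, level at the digits shown with compound 3 `C[C@H]1[C@H](NCc2cc(C3CCCCC3)cs2)C[C@H]2C[C@@H]1C2(C)C`, which gives 780 nM; together they stand lowest of the three. Compound 2 `C=Cc1csc(CN[C@@H]2C[C@H]3C[C@@H]([C@H]2C)C3(C)C)c1` gives 6250 nM, the highest number. For the measured compounds named here, the only measured step, an 8.0-fold lower number from compound 2 to compound 3 (0.90 log units; beyond the scatter), concerns a substituent on the aromatic ring, not the ring itself.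

Compound 4 `Cc1csc(CN[C@@H]2C[C@H]3C[C@@H]([C@H]2C)C3(C)C)n1` differs from compound 1 in one place: 4-methyl-1,3-thiazol-2-yl in place of 5-methylthiophen-2-yl on a saturated chain carbon bound to an amine nitrogen. Going by the values given here, no measured step exchanges one aromatic ring for another, so nothing among the measured compounds speaks directly to this change. With that in mind, only a small step is expected, a 1.3-fold higher number from compound 1 to compound 4 (0.11 log units; within the scatter), with direction uncertain and plausibly within the scatter. For compound 4 an estimate of 1000 nM is therefore expected, within a range from 390 nM to 3125 nM.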

Compound 4, minimum cytotoxic concentration: > 100000 nM
Compound 4: no number, only a limit; the forecaster's own chance of this, stated with the estimate: 5%; middle value at least 100-fold (2.00 log units) from the limit.
By their numbers in this assay, from the lowest: compounds 1 and 3 (each within the scatter of the next); then compound 2. At a limit, above all of these: compound 4.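

On a saturated chain carbon bound to an amine nitrogen, the aromatic ring itself proves decisive in this assay: 4-methyl-1,3-thiazol-2-yl in place of 5-methylthiophen-2-yl gives an at least 120-fold higher number from compound 1 to compound 4 (2.10 log units; beyond the scatter). The earlier compounds had shown only what a change of substituent on the ring does, whereas here a ring with the same count of heavy atoms but one more hetero atom moves the read-out far towards lower toxicity in this test. For compound 4 the value of > 100000 nM is a limit and not a number: the limit of > 100000 nM in this assay, at which 1 of the 4 values shown sits.

Compound 4 differs from compound 1 in both the ring hetero atoms and the place of the methyl, and the compounds shown do not separate these two changes. They also leave open how a pyridyl group would read in this place.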